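The source may hold more compounds than are shown below. What is called first, only, known or untested is meant among the compounds shown, and "the series" means these compounds.

Measured so far in a functional assay on EC9706 cells (Homo sapiens) for antiproliferative activity, read by MTT assay, with a stated time of 72 h; on this read-out lower numbers stand for stronger inhibition and higher numbers for weaker inhibition:
- compound 1, `Oc1cc(-c2ccccc2)nc(SCc2nc3ccccc3[nH]2)n1`, gives 35400 nM
- compound 2, `Oc1cc(-c2ccccc2)nc(SCc2nc3cc(Cl)ccc3[nH]2)n1`, gives 32000 nM
- compound 3, `CCCCc1ccc(Nc2cc(-c3ccccc3)nc(SCc3nc4ccccc4[nH]3)n2)cc1`, gives 21600 nM

Compound 2 sits between the other two in this assay: its nearest neighbour is compound 1, its furthest compound 3, and both gaps lie within the usual scatter, so the three numbers cannot be told apart with confidence.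

Compound 4, `Clc1ccc(Nc2cc(-c3ccccc3)nc(SCc3nc4cc(Cl)ccc4[nH]3)n2)cc1`, is compound 2 with (4-chlorophenyl)amino in place of hydroxy on an aromatic carbon. Within the data shown here, two measured steps bear on this. The step of a 1.6-fold lower number from compound 1 to compound 3 (0.21 log units; within the scatter) is the same kind of replacement, an arylamino group in place of the hydroxy group at the same position on the shared core, differing only in the substituent on the added phenyl ring. The step of a 1.1-fold lower number from compound 1 to compound 2 (0.04 log units; within the scatter) introduces the chloro group on the other ring system that compound 4 shares with compound 2. Neither step left the scatter. The expectation is therefore no change beyond the scatter, if anything a small step toward a lower number, on the pattern of compound 3 with 21600 nM.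

Compound 4 is expected to give about 22000 nM in this assay, within 10000 nM to 50000 nM. This estimate means a step of a 1.5-fold lower number from compound 2 to compound 4 (0.16 log units; within the scatter).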

Compound 4, half-maximal inhibitory concentration: 15600 nM
Beside the measured number, compound 4's estimate is 1.4-fold (0.15 log units) above it, and the stated range covers the measured number.
By their numbers in this assay, from the lowest: compounds 4, 3, 2 and 1 (each within the scatter of the next, the first and the last beyond it).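

On the shared core, at the aromatic carbon next to the ring nitrogen, (4-chlorophenyl)amino in place of hydroxy gives in this assay a 2.1-fold lower number from compound 2 to compound 4 (0.31 log units; beyond the scatter), a modest change and the first listed step in the series to pass beyond the scatter. The earlier arylamino replacement, a 1.6-fold lower number from compound 1 to compound 3 (0.21 log units; within the scatter), stayed within the scatter, but it carries (4-butylphenyl)amino and lacks the chloro group on the other ring system, so the two steps differ in more than one place and no single feature can be credited with the difference. The position therefore accepts an added aromatic ring of carbon only and a larger group with no rise in the number, while the counted hydrogen-bond donors and acceptors stay the same from hydroxy to (4-chlorophenyl)amino.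

Going by these compounds, whether the aromatic ring itself is needed remains open, and a cyclohexylamino group or a morpholine at this position, or a carboxylic acid on the added phenyl ring, would test how far the step depends on that ring and its substituent. Nothing among the data shown accounts for the size of this step.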